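Iodo in place of chloro: a small step expected

A few compounds are considered here, and "the series" means these few. Any claim that something is new, unique, unknown or untested is made for them only; others in the source may bear on it.

In a functional assay on HL-60 cells (Homo sapiens) for antiproliferative activity, with a stated time of 48 h (a higher number here means that more compound is needed for the effect, a lower number that less compound is needed), compound 1 `O=C(CCCCCCC(=O)Nc1ccc(C(F)(F)F)cc1)NO` gives 1540 nM and compound 2 `O=C(CCCCCCC(=O)Nc1ccc(Cl)cc1)NO` gives 1870 nM as its result. For the measured compounds named here, compound 2 thus stands level with compound 1 within the scatter, and these two are the only measured compounds. Compound 3 `O=C(CCCCCCC(=O)Nc1ccc(I)cc1)NO` carries iodo in place of chloro on an aromatic carbon, the change counting as iodo in place of chloro on an aromatic carbon in full. Going by the values given here, no measured compound yet carries iodo. With only a 1.2-fold higher number from compound 1 to compound 2 (0.08 log units; within the scatter) as a guide, for chloro in place of trifluoromethyl on an aromatic carbon, no step beyond the scatter is expected in this assay and no direction can be given. The expected change is a 1.0-fold lower number from compound 2 to compound 3 (0.02 log units; within the scatter) and so stays within the scatter. For compound 3 the estimated value is 1800 nM with an expected range from 1000 nM to 3200 nM in this test.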

Compound 3, half-maximal effective concentration: 850 nM
Compound 3: the middle estimate sits 2.1-fold (0.33 log units) above what was measured; the measured number lies below the stated range.
By their numbers in this assay, from the lowest: compounds 3, 1 and 2 (each within the scatter of the next, the first and the last beyond it).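

For the compounds shown here, until now the group on this aromatic carbon, para to a large group, had produced no difference beyond the scatter in this assay, but iodo in place of chloro gives a 2.2-fold lower number from compound 2 to compound 3 (0.34 log units; beyond the scatter) and so the first step that passes it, if only modestly. Iodo in place of trifluoromethyl gives a 1.8-fold lower number from compound 1 to compound 3 (0.26 log units; within the scatter) and leaves the two compounds level within the scatter, so the only clear separation at this position lies between compound 2 and compound 3. Nothing available explains this step. Three groups at one position are too few to support a rule about substituents there. From the compounds shown here alone, how bromo, fluoro, methoxy or an amine on the same carbon would fall, and whether the step would hold with a longer chain in the shared core, remains open.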